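Alkyne substituent swap on the shared core: silicon-bearing group to butyl

The source may report more compounds than this note shows. Statements on the series, on what has been measured and on what is new or still open speak of the compounds shown alone.

Compound 1 `C[Si](C)(C)C#Cc1c[nH]c(=O)[nH]c1=O` is tested in an ADME assay on MRC5 cells (Homo sapiens) for cytotoxicity, read by MTT assay (a lower number here means that less compound is tolerated, a higher number that more compound is tolerated), where compound 1 gives 124000 nM. Within the data shown here, this is the highest of the two numbers so far; compound 2 `O=c1[nH]c(=O)n([C@@H]2O[C@H](CO)[C@@H](O)[C@H]2O)cc1C#CC1CC1` gives 24200 nM in this assay, a lower number, beyond the scatter of compound 1. Compound 3 `CCCCC#Cc1c[nH]c(=O)[nH]c1=O` is not yet measured in this assay. It differs from compound 1 by a group of 4 heavy atoms (4 carbon; no ring) in place of a group of 4 heavy atoms (3 carbon, 1 silicon; no ring), on a triple-bonded carbon: butyl enters on a triple-bonded carbon whose other neighbour is a triple-bonded carbon. Among the measured compounds shown here, no measured pair shows this change, so only a modest step is expected, most likely toward a somewhat lower number, as a 1.4-fold lower number from compound 1 to compound 3 (0.14 log units; within the scatter). Compound 3 is estimated at 90000 nM, within 35000 nM to 230000 nM.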

Compound 3, half-maximal cytotoxic concentration: 113000 nM
Compound 3: middle estimate off by 1.3-fold (0.10 log units), on the low side; the range from low to high includes it.
By their numbers in this assay, from the lowest: compound 2; then compounds 3 and 1 (each within the scatter of the next).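

In this assay the swap of the silicon-bearing group for butyl on a triple-bonded carbon gives a 1.1-fold lower number from compound 1 to compound 3 (0.04 log units; within the scatter), so silicon is not needed at this position for tolerance at the level of compound 1. This one step holds for an open chain of the same heavy-atom count on the shared core. No measured data offer a reason for the match.

As far as these compounds go, whether a longer chain, an amine or a carboxylic acid at this position stays at the same level remains open. Compound 2 differs from compound 1 and compound 3 in more than one place, so it cannot settle this.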